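Swapping the Benzylic Ring and Expected Cytotoxicity

The source may hold more compounds than are shown below. What is called first, only, known or untested is meant among the compounds shown, and "the series" means these compounds.

In an ADME assay on Vero cells (Chlorocebus sabaeus) for cytotoxicity, read by fluorescence and resazurin assay, with a stated time of 72 h (on this read-out lower numbers stand for stronger inhibition and higher numbers for weaker inhibition), compound 1 `C[C@H]1COC2(CCN(c3nc(=O)c4cc(C(F)(F)F)cc([N+](=O)[O-])c4s3)CC2)O1` returns > 100000 nM, which is a limit of the assay rather than a number. The other value shown is the limit of > 100000 nM in this assay, at which 1 of the 2 values shown sits. Among the measured compounds shown here, compound 2 `COc1ccc(CNC(=O)c2sc3c([N+](=O)[O-])cc(C(F)(F)F)cc3[n+]2[O-])cc1` gives 76000 nM in this assay, the only measured number here. Compound 3 `O=C(NCc1ccc2c(c1)CCO2)c1sc2c([N+](=O)[O-])cc(C(F)(F)F)cc2[n+]1[O-]` carries a group of 9 heavy atoms (8 carbon, 1 oxygen; one five-membered non-aromatic ring with 1 hetero atom, one six-membered aromatic ring of carbon only) in place of a group of 8 heavy atoms (7 carbon, 1 oxygen; one six-membered aromatic ring of carbon only), on a saturated chain carbon bound to an amide-type nitrogen. For the measured compounds named here, no measured step of this kind is available, so the change is expected to shift the number little, remaining within the usual scatter. Compound 3 is therefore expected to give 80000 nM, between 35000 nM and 200000 nM, in this assay, an expected step of a 1.1-fold higher number from compound 2 to compound 3 (0.02 log units; within the scatter).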

Compound 3, half-maximal inhibitory concentration: > 100000 nM
Compound 3 ended at the assay's limit (the forecaster's own chance of this, stated with the estimate: 35%); middle value at least 1.2-fold (0.09 log units) away from the limit.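

Setting the group with a five-membered non-aromatic ring in place of 4-methoxyphenyl, on a saturated chain carbon bound to an amide-type nitrogen, gives an at least 1.3-fold higher number from compound 2 to compound 3 (0.11 log units; that floor lies within the scatter) in this assay. So this place accepts the added ring without a lower number appearing. The reading for compound 3 is a limit of the assay and not a number, and it joins that of compound 1: the limit of > 100000 nM in this assay, at which 2 of the 3 values shown sit.

On these data alone, the exact size of this step stays open. So does whether an amine or a carboxylic acid at this place would bring a lower number.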